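Changing the urea substituent on a sulfonate-fused nucleoside

The compounds below may be only part of what the source reports. "The series", "measured", "known", "first", "only" and "open" are said of these compounds alone.

Compound 1 `CCNC(=O)NC1=CS(=O)(=O)O[C@@]12[C@@H](CO[Si](C)(C)C(C)(C)C)O[C@@H](n1cc(C)c(=O)n(C)c1=O)[C@@H]2O[Si](C)(C)C(C)(C)C` carries an ethylcarbamoyl group on the amine nitrogen of its shared core. In a functional assay on CCRF-CEM cells (Homo sapiens) (a lower number here means that less compound is tolerated, a higher number that more compound is tolerated), compound 1 gives 4260 nM, the lowest of the two measured values. Compound 2 `Cc1cn([C@@H]2O[C@H](CO[Si](C)(C)C(C)(C)C)[C@@]3(OS(=O)(=O)C=C3NCCC(=O)O)[C@H]2O[Si](C)(C)C(C)(C)C)c(=O)n(C)c1=O` differs in one place, with 2-carboxyethyl in place of ethylcarbamoyl on that amine nitrogen, and in this assay compound 2 gives 19400 nM; the step of a 4.6-fold higher number from compound 1 to compound 2 (0.66 log units; beyond the scatter) is modest but beyond the scatter. Compound 3 `C=C(C)C(=O)NC(=O)NC1=CS(=O)(=O)O[C@@]12[C@@H](CO[Si](C)(C)C(C)(C)C)O[C@@H](n1cc(C)c(=O)n(C)c1=O)[C@@H]2O[Si](C)(C)C(C)(C)C` has not been measured. It differs from compound 1 by (1-methylethenyl)carbonyl in place of ethyl on an amide-type nitrogen. Among the compounds with values here, the only measured step concerns a different part of the substituent, so no step bears directly on this change. With nothing to point in either direction, compound 3 is expected to stay close to compound 1, an estimated step of a 1.4-fold lower number from compound 1 to compound 3 (0.15 log units; within the scatter). In this assay compound 3 is estimated at 3000 nM, within a range from 800 nM to 12000 nM.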

Compound 3, half-maximal cytotoxic concentration: 1200 nM
The estimate for compound 3 lay 2.5-fold (0.40 log units) above the measured number; the range from low to high includes it.
By their numbers in this assay, from the lowest: compound 3; then compound 1; then compound 2.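

The estimate assumed that the far end of the substituent would matter little, but in this assay this position does respond: a 3.6-fold lower number from compound 1 to compound 3 (0.55 log units; beyond the scatter). Replacing ethyl with (1-methylethenyl)carbonyl on the amide-type nitrogen therefore gives compound 3 the lowest number of the three, meaning the least compound is tolerated. Within the data shown here, the wider difference on the amine nitrogen gives the largest step so far, a 16-fold lower number from compound 2 to compound 3 (1.21 log units; beyond the scatter), although no available measurement explains either step.

The compounds shown leave open which part of the (1-methylethenyl)carbonyl group goes with the lower number. An acetyl group, which keeps the carbonyl without the double bond, and a longer alkyl chain in place of ethyl would help separate the effect of the carbonyl and double bond from that of added size.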